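This account rests on a few compounds, and the source may have more. Where it says the series, first, only, none or still open, it means among the compounds named here.

Of the compounds shown here, three built on one shared core have so far been tested in a functional assay on PC-12 cells (Rattus norvegicus) for cytotoxicity, read by MTT assay, with stated times of 3 h and 2 h, tested at 5 uM; on this read-out higher numbers stand for a stronger effect at the one concentration tested and lower numbers for a weaker effect. Compound 1 `CC(=O)c1cc2ccc(OCCCn3cc(CNC(=O)CCCCC4CCSS4)nn3)cc2oc1=O` carries an acetyl group on the core and gives 37.5%. Compound 2 `O=C(CCCCC1CCSS1)NCc1cn(CCCOc2ccc3cc(-c4ccc(Cl)c(Cl)c4)c(=O)oc3c2)nn1` gives 44.7%, and compound 3 `O=C(CCCCC1CCSS1)NCc1cn(CCCCOc2ccc3ccc(=O)oc3c2)nn1` gives 52.8%. Among these three numbers compound 3 stands highest: its nearest neighbour is compound 2, lower by an amount within the scatter, while compound 1 lies furthest away, lower by an amount beyond the scatter.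

Compound 4 `O=C(CCCCC1CCSS1)NCc1cn(CCCCOc2ccc3cc(-c4ccccc4)c(=O)oc3c2)nn1` differs from compound 3 in one place only: phenyl in place of hydrogen on an aromatic carbon. Within the data shown here, the one measured step that touches the same position is a number 7.2 percentage points higher from compound 1 to compound 2 (within the scatter), where the group at that position also changed from a small substituent to a substituted phenyl ring. That step stayed within the scatter. Compound 2, which carries a dichlorophenyl at this position, and compound 3, which carries a hydrogen there, also sit within the scatter of each other, though they differ in a second place as well.

Putting a phenyl at this position is therefore expected to move the number little, so the expected step of a number 0.8 percentage points lower from compound 3 to compound 4 (within the scatter) is small. Compound 4 is estimated at 52%, with a likely range from 38% to 66% in this assay .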

Compound 4, a percentage reported as activity, at one concentration (the size of the read-out at that concentration, not a potency): 32.8%
The estimate for compound 4 lay 19.2 percentage points above the measured number; measured number outside the range, below it.
By their numbers in this assay, from the lowest: compounds 4, 1, 2 and 3 (each within the scatter of the next, the first and the last beyond it).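

In this assay, the step of a number 20 percentage points lower from compound 3 to compound 4 (beyond the scatter) shows that this aromatic carbon, two atoms from the ring oxygen, is not indifferent to what it carries. Placing a phenyl ring where a hydrogen stood changes the number by more than the usual scatter of repeated measurements. The earlier step at the same place, a number 7.2 percentage points higher from compound 1 to compound 2 (within the scatter), exchanged one substituent for another and did not compare a ring with a bare hydrogen, so only the new pair shows what adding a phenyl ring there does on its own. Nothing in the available data accounts for this fall, so the result records a change in the read-out without giving its cause.

From the compounds shown here alone, it remains open whether the fall goes with any added group at this carbon or with a ring in particular: a methyl group or a saturated cyclohexyl ring in the same place would help to separate the two. Also open, going by these compounds, is whether a phenyl ring carrying an amine or a carboxylic acid would behave as the plain phenyl of compound 4 does.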